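Anilino swap on the shared core: from bromophenyl to hydroxyphenyl

The compounds below may be only part of what the source reports. "The series", "measured", "known", "first", "only" and "open" are said of these compounds alone.

Measured compounds:
compound 1 `C#CCSc1nc(Nc2cccc(Cl)c2)c2ccncc2n1`, 1090 nM
compound 2 `C#CCSc1nc(Nc2ccc(Br)cc2)c2ccncc2n1`, 56200 nM

In a functional assay on HepG2 cells (Homo sapiens) for inhibition, read by MTT assay, with a stated time of 72 h (a higher number here means a weaker inhibitor, a lower number a stronger inhibitor), compound 2 gives the highest number of the two, with compound 1 the nearest at a lower value. For the measured compounds named here, the only measured step, a 52-fold higher number from compound 1 to compound 2 (1.71 log units; beyond the scatter), shows that the substitution pattern of the aryl group on the anilino nitrogen changes the result by a large amount. Compound 3 `C#CCSc1nc(Nc2ccccc2O)c2ccncc2n1` carries the change (2-hydroxyphenyl in place of 4-bromophenyl on a nitrogen on an aromatic ring). No measured step involves a hydroxyl on this ring, so the direction of the step is not shown by the data; the one step available only tells that such aryl changes can be large. Compound 3 is therefore expected to move away from compound 2, most likely toward a lower number, by a 4.7-fold lower number from compound 2 to compound 3 (0.67 log units; beyond the scatter), with wide uncertainty. The estimate for compound 3 in this assay is 12000 nM, within a range from 1500 nM to 90000 nM.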

Compound 3, half-maximal inhibitory concentration: > 80000 nM
Compound 3 was reported as a limit; the forecaster's own chance of this, stated with the estimate: 15%; middle value at least 6.6-fold (0.82 log units) from the limit.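

In this assay, compound 3 is reported only as a limit: the limit of > 80000 nM in this assay, at which 1 of the 3 values shown sits. The step is an at least 1.4-fold higher number from compound 2 to compound 3 (0.15 log units; that floor lies within the scatter), so 2-hydroxyphenyl cannot be placed in any order relative to 4-bromophenyl on this nitrogen on an aromatic ring. The 3-chlorophenyl of compound 1 stands clearly apart, with an at least 73-fold higher number from compound 1 to compound 3 (1.86 log units; beyond the scatter), which leaves compound 1 the strongest of the three in this assay and shows that a hydroxyl-bearing ring in this place does not bring the number near that of compound 1.

As far as these compounds go, how far compound 3 lies past its limit remains open, and with it any ranking against compound 2. Also open, from the compounds shown here alone, is whether a methoxy group or an amine on this ring would keep the number of compound 1 or lose it as the 4-bromophenyl and 2-hydroxyphenyl rings do.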